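The compounds below may be only part of what the source reports. "The series", "measured", "known", "first", "only" and "open" are said of these compounds alone.

Three close relatives of a shared core have been measured in an in vitro functional assay on Sf9 cells for antagonist activity at histamine H2 receptor (Homo sapiens); a higher number here means a more potent compound, by a factor of ten per unit of this negative logarithm, a lower number a less potent compound. Compound 1 `N#C/N=C(\NCCCc1ccccc1)NCCCc1c[nH]cn1` gives 5.25. Compound 2 `N#C/N=C(/NCCCCc1c[nH]cn1)NCCCc1ccccc1` gives 5.25. Compound 3 `N#C/N=C(/NCCCCCc1c[nH]cn1)NCCCc1ccccc1` gives 5.28, a value that sits within the usual scatter of both compound 1 and compound 2, so the three cannot be told apart on these numbers. The measured steps all change the chain on the imidazole side: no change at the digits printed from compound 1 to compound 2 (within the scatter), a number 0.03 log units higher from compound 1 to compound 3 (within the scatter) and a number 0.03 log units higher from compound 2 to compound 3 (within the scatter). None of them touches the other end of the core.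

Compound 4 `CN/C(=N\C#N)NCCCCCc1c[nH]cn1` differs from compound 3 by hydrogen in place of phenethyl on a saturated chain carbon bound to an amine nitrogen. Among the compounds with values here, no measured step covers a change of this kind, so the three steps above give no guide to its size; they only show that chain length on the imidazole side left this assay unmoved. With the aromatic ring removed, a modest loss is expected, and the estimate for compound 4 in this assay is 5, with a range from 4.4 to 5.6, meaning an expected step of a number 0.28 log units lower from compound 3 to compound 4 (within the scatter) that may well fall within the scatter.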

Compound 4, negative logarithm of the antagonist equilibrium constant: 5.66
Estimate against measurement, compound 4: 0.66 log units below; the measured number lies above the stated range.
By their numbers in this assay, from the lowest: compounds 1, 2 and 3 (each within the scatter of the next); then compound 4.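

Taking away the phenethyl group costs no potency at this position: in this assay, hydrogen in place of phenethyl on a saturated chain carbon bound to an amine nitrogen gives a number 0.38 log units higher from compound 3 to compound 4 (beyond the scatter) and so reverses the expected direction. The earlier steps shown here changed only the chain on the imidazole side and stayed within the scatter, whereas this change at the other end of the shared core moves the number beyond it, and compound 4 keeps its potency without the aromatic ring of the phenethyl group. No measurement shown here accounts for this rise.

An ethyl, benzyl or cyclohexylmethyl group in the same place could show whether potency changes gradually with the size of the group or depends on the aromatic ring. As far as these compounds go, it also remains open whether the imidazole-side chain length still makes no difference once the phenethyl group is gone.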